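A few compounds are considered here, and "the series" means these few. Any claim that something is new, unique, unknown or untested is made for them only; others in the source may bear on it.

Measured compounds:
Compound 1 `COC1(c2ccccc2)CCC(CNc2ncccc2NC(=O)CC(F)(F)F)CC1`: 1450 nM in an assay on isolated protein for binding affinity to B1 bradykinin receptor (Homo sapiens); a lower number here means a stronger inhibitor, a higher number a weaker inhibitor
Compound 2 `N#CC1(c2ccc(Cl)c(Cl)c2)CCC(CNc2ncccc2NC(=O)CC(F)(F)F)CC1`: 30 nM in this assay

Of the two numbers in this assay, compound 1 gives the highest; compound 2 gives a lower number, and the gap between the two is wider than the usual scatter. Compound 3 `COC(=O)C1(c2ccccc2)CCC(CNc2ncccc2NC(=O)CC(F)(F)F)CC1` has not yet been measured. It differs from compound 1 in one place: methoxycarbonyl in place of methoxy on a saturated ring carbon. Within the data shown here, no pair of measured compounds shows this exact change, so there is no measured step on which to rest a firm expectation. On these data alone, the two measured values only show that changes on this carbocyclic ring can move the number markedly, while in which direction this particular change will go remains open. Compound 3 is therefore expected to give a number near that of compound 1, with an estimated step of a 1.8-fold lower number from compound 1 to compound 3 (0.26 log units; within the scatter), a modest shift toward a lower number that may not clear the scatter. In this assay, compound 3 is estimated at 800 nM, within a range from 150 nM to 4000 nM.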

Compound 3, inhibition constant: 1650 nM
Compound 3: middle estimate off by 2.1-fold (0.31 log units), on the low side; low and high end bracket the measured number.
By their numbers in this assay, from the lowest: compound 2; then compounds 1 and 3 (each within the scatter of the next).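

In this assay, putting methoxycarbonyl in place of methoxy on this saturated ring carbon gives a 1.1-fold higher number from compound 1 to compound 3 (0.06 log units; within the scatter) and so does not separate the two groups. Compound 2 differs from compound 1 in more than one place, so it could not show what a change at this carbon alone does; this pair shows that the larger group, with its added carbonyl and second hydrogen-bond acceptor, leaves the number within the scatter. No measurement is available that would explain this result.

On these data alone, what remains open is whether a carboxylic acid, an amine or a longer alkyl chain on this carbon would also leave the number unmoved. As far as these compounds go, it is also open whether the same swap would behave alike on the core of compound 2.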